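Urea aryl variation on a shared core

The source may hold more compounds than are shown below. What is called first, only, known or untested is meant among the compounds shown, and "the series" means these compounds.

Measured so far in a functional assay on HCT-15 cells (Homo sapiens) for inhibition, read by sulforhodamine B assay, with a stated time of 48 h, tested at 0.1 uM; on this read-out higher numbers stand for a weaker effect at the one concentration tested and lower numbers for a stronger effect:
compound 1 `O=C(Nc1cccc(-n2cc(-c3ccncc3)c(-c3cc(O)cc(Cl)c3)n2)c1)Nc1ccc(Cl)c(Cl)c1`: 95%
compound 2 `COc1cc(Cl)cc(-c2nn(-c3cccc(NC(=O)Nc4ccc(Cl)c(C(F)(F)F)c4)c3)cc2-c2ccncc2)c1`: 54%
compound 3 `COc1cc(Cl)cc(-c2nn(-c3cccc(NC(=O)Nc4cc(C(F)(F)F)cc(C(F)(F)F)c4)c3)cc2-c2ccncc2)c1`: 90%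

Compound 3 stands second highest of the three numbers. Its nearest neighbour is compound 1, whose 95% lies within the scatter of it; the furthest is compound 2, whose 54% lies beyond the scatter, a lower number and so a stronger effect at the single concentration.

Compound 4 `COc1cc(Cl)cc(-c2nn(-c3cccc(NC(=O)Nc4cccc(C(F)(F)F)c4)c3)cc2-c2ccncc2)c1` differs from compound 3 in one place: hydrogen in place of trifluoromethyl on an aromatic carbon. Within the data shown here, no single-point step between measured compounds exists to size this change. The step from compound 3 to compound 4 is expected to be a number 12 percentage points lower from compound 3 to compound 4 (beyond the scatter), a modest move toward a lower number, not clearly beyond the scatter. Compound 4 is estimated at 78%, between 50% and 100%.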

Compound 4, a percentage reported as activity, at one concentration (the size of the read-out at that concentration, not a potency): 83%
The estimate for compound 4 lay 5 percentage points below the measured number; low and high end bracket the measured number.
By their numbers in this assay, from the lowest: compound 2; then compounds 4, 3 and 1 (each within the scatter of the next, the first and the last beyond it).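

In this assay, hydrogen in place of trifluoromethyl gives a number 7 percentage points lower from compound 3 to compound 4 (within the scatter), so at this position the change leaves no readable difference. Hydrogen in place of chloro on an aromatic carbon gives a number 29 percentage points higher from compound 2 to compound 4 (beyond the scatter), so the chloro of compound 2 marks a change that goes beyond the scatter, unlike the loss of trifluoromethyl. Nothing on hand bears on the reason for either step.

Open, as far as these compounds go, is whether a fluoro, a methyl or an amine on the carbon carrying that chloro would give a number as low as that of compound 2.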